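The source may report more compounds than this note shows. Statements on the series, on what has been measured and on what is new or still open speak of the compounds shown alone.

Measured in an ADME assay on the whole organism (Mus musculus, strain CD-1) for pharmacokinetics, at a dose of 10 mg/kg by the oral route (on this read-out higher numbers stand for higher exposure at the dose given and lower numbers for lower exposure), so far:
- compound 1 `CCOc1cc([C@](O)(CCN(C)C)[C@@H](c2cc3cc(Br)ccc3nc2OC)c2ccnc(OC)c2OC)cc(OC)n1` gives 12700 ng.h/mL
- compound 2 `CCCOc1cc([C@](O)(CCN(C)C)[C@@H](c2cc3cc(Br)ccc3nc2OC)c2ccnc(OC)c2OC)cc(OC)n1` gives 10900 ng.h/mL
- compound 3 `COc1cc([C@](O)(CCN(C)C)[C@@H](c2cc3cc(Br)ccc3nc2OC)c2ccnc(OC)c2OC)cc(OC(F)F)n1` gives 9800 ng.h/mL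

Compound 3 stands level with the other two: a 1.3-fold lower number from compound 1 to compound 3 (0.11 log units; within the scatter) and a 1.1-fold lower number from compound 2 to compound 3 (0.05 log units; within the scatter) are both within the scatter. Compound 4 `COc1nc2ccc(Br)cc2cc1[C@@H](c1ccnc(OC)c1OC)[C@@](O)(CCN(C)C)c1cc(SC)nc(SC)c1` is still unmeasured. Its difference from compound 3 is a group of 10 heavy atoms (7 carbon, 1 nitrogen, 2 sulfur; one six-membered aromatic ring with 1 hetero atom) in place of a group of 12 heavy atoms (7 carbon, 1 nitrogen, 2 oxygen, 2 fluorine; one six-membered aromatic ring with 1 hetero atom), on a saturated chain carbon bound to an oxygen on a saturated carbon and two saturated chain carbons on a saturated chain carbon bound to an oxygen on a saturated carbon and two saturated chain carbons.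

The nearest evidence is those two steps and a 1.2-fold lower number from compound 1 to compound 2 (0.07 log units; within the scatter), all of which alter only what sits on an oxygen on an aromatic ring. Among the compounds with values here, no measured compound contains sulfur, so this evidence is thin. No step beyond the scatter is expected in this assay, and the estimated change is a 1.2-fold lower number from compound 3 to compound 4 (0.09 log units; within the scatter). Compound 4 is estimated at 8000 ng.h/mL, with a range from 3000 ng.h/mL to 19000 ng.h/mL expected.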

Compound 4, area under the concentration-time curve: 3900 ng.h/mL
Beside the measured number, compound 4's estimate is 2.1-fold (0.31 log units) above it, and the stated range covers the measured number.
By their numbers in this assay, from the lowest: compound 4; then compounds 3, 2 and 1 (each within the scatter of the next).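

Until now, every change in this assay altered only what sits on an oxygen on an aromatic ring, and none went beyond the scatter. Within the data shown here, putting sulfur in place of those oxygens is the first change that does, giving a 2.5-fold lower number from compound 3 to compound 4 (0.40 log units; beyond the scatter) and a 2.8-fold lower number from compound 2 to compound 4 (0.45 log units; beyond the scatter) and a 3.3-fold lower number from compound 1 to compound 4 (0.51 log units; beyond the scatter). Nothing measured here says why exposure fell. From the compounds shown here alone, since both ring substituents differ in compound 4, it remains open whether a single methylthio group paired with a methoxy group would lower exposure as well, or how a methylsulfonyl group would behave.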